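An Indolyl Replaces a Pyridyl: What to Expect

The source may report more compounds than this note shows. Statements on the series, on what has been measured and on what is new or still open speak of the compounds shown alone.

Two compounds have been measured in a functional assay on HepG2 cells (Homo sapiens) for antiproliferative activity, read by MTT assay, with a stated time of 48 h; a higher number here means a weaker inhibitor, a lower number a stronger inhibitor:
compound 1 `Clc1cccc(Nc2ncnc3ccc(NCc4cccs4)cc23)c1` gives 3580 nM;
compound 2 `O=C(/C=C/c1cccnc1)Nc1ccc2ncnc(Nc3cccc(Cl)c3)c2c1` gives 9120 nM.

Compound 2 stands at the higher of the two numbers, and compound 1 sits at a number lower by a margin beyond the usual scatter. Among the compounds with values here, since the two compounds differ in more than one place, no single step can be isolated between them, and nothing more than the two values themselves can be read from them.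

Compound 3 `O=C(/C=C/c1c[nH]c2ccccc12)Nc1ccc2ncnc(Nc3cccc(Cl)c3)c2c1` differs from compound 2 in one place only: 1H-indol-3-yl in place of pyridin-3-yl on a double-bonded chain carbon bound to a double-bonded chain carbon. No change of this kind has been measured among the compounds shown, so the data give no direct guide to its size or direction in this assay. With that reservation, a small step toward a lower number is expected, of a size that may still lie within the scatter. Compound 3 is therefore estimated to give 6000 nM, with a range from 2000 nM to 18000 nM. This estimate means an expected step of a 1.5-fold lower number from compound 2 to compound 3 (0.18 log units; within the scatter), modest and uncertain in direction.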

Compound 3, half-maximal inhibitory concentration: 7020 nM
For compound 3 the middle estimate is 1.2-fold (0.07 log units) below the measured one, and the stated range covers the measured number.
By their numbers in this assay, from the lowest: compounds 1, 3 and 2 (each within the scatter of the next, the first and the last beyond it).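

In this assay, 1H-indol-3-yl in place of pyridin-3-yl on a double-bonded chain carbon bound to a double-bonded chain carbon gives a 1.3-fold lower number from compound 2 to compound 3 (0.11 log units; within the scatter), so compound 2 and compound 3 cannot be told apart in this read-out. Within the data shown here, this is the first single-place comparison, and it involves a substantial change in what is counted: 6 heavy atoms become 9, one six-membered aromatic ring with 1 hetero atom becomes a five-membered aromatic ring with 1 hetero atom plus a six-membered aromatic ring of carbon only, and 1 hydrogen-bond acceptor gives way to 1 hydrogen-bond donor. In this one pair, all of that comes with no step beyond the scatter, though a single pair cannot show whether the same would hold for other groups at this place.

From the compounds shown here alone, whether a plain phenyl, a dimethylamino group, a carboxylic acid or a longer chain carrying an amine at this place would give a step beyond the scatter remains open. Nothing available here bears on why compound 2 and compound 3 fall so close together.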